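The source may hold more compounds than are shown below. What is called first, only, known or untested is meant among the compounds shown, and "the series" means these compounds.

Values in a functional assay on GBM2 cells (Homo sapiens) for antiproliferative activity, read by WST assay, with a stated time of 72 h; on this read-out lower numbers stand for stronger inhibition and higher numbers for weaker inhibition:
- compound 1 `O=C(Nc1cccc(Cl)c1)Nc1cc2ncncc2cc1OCc1ccccc1Cl`: 2100 nM
- compound 2 `O=C(Nc1cccc(F)c1)Nc1cc2ncncc2cc1OCc1ccccc1Cl`: 3200 nM
- compound 3 `O=C(Nc1cc2ncncc2cc1OCc1ccccc1Cl)Nc1cccc2ccccc12`: 2900 nM

In this assay compound 1 gives 2100 nM, and it cannot be separated from the other two compounds: a 1.5-fold higher number from compound 1 to compound 2 (0.18 log units; within the scatter), and a 1.4-fold higher number from compound 1 to compound 3 (0.14 log units; within the scatter). The remaining pair behaves the same way: a 1.1-fold lower number from compound 2 to compound 3 (0.04 log units; within the scatter).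

Next in the series is compound 4 `O=C(Nc1cccc(Cl)c1)Nc1cc2ncncc2cc1OCc1ccccc1`, which differs from compound 1 as follows: hydrogen in place of chloro on an aromatic carbon. This is hydrogen in place of chloro on an aromatic carbon, ortho to a large group, so that 2-chlorobenzyl becomes benzyl.

Within the data shown here, no measured step touches this group, since compound 1, compound 2 and compound 3 all carry 2-chlorobenzyl. The measured steps bear on the question only indirectly. They are all changes at the other end of the molecule, and the data give no direct reading for the loss of this chloro. The closest in kind is a 1.5-fold higher number from compound 1 to compound 2 (0.18 log units; within the scatter), which also alters a halogen on an aromatic carbon, though on a different ring.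

No step beyond the scatter is therefore expected in this assay, and no direction can be firmly assigned. The estimated step is a 1.3-fold higher number from compound 1 to compound 4 (0.12 log units; within the scatter). For compound 4 the expected value is 2800 nM, with an estimated range of 1100 nM to 7000 nM.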

Compound 4, half-maximal inhibitory concentration: 4100 nM
Compound 4: the middle estimate sits 1.5-fold (0.17 log units) below what was measured; measured number inside the range.
By their numbers in this assay, from the lowest: compounds 1, 3, 2 and 4 (each within the scatter of the next).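

In this assay, among these compounds, the first reading at this position is hydrogen in place of chloro on the 2-chlorobenzyl group, which gives a 2.0-fold higher number from compound 1 to compound 4 (0.29 log units; within the scatter) and so cannot be distinguished from no change. The chloro shared by compounds 1, 2 and 3 can therefore be removed, leaving benzyl, without a step beyond the scatter on this read-out, although this rests on a single pair of compounds. Nothing available gives a reason for the size of this step.

The compounds shown leave open whether a methoxy group or an amine in place of this chloro, or a longer chain in place of benzyl, would give a step beyond the scatter. Among the compounds shown here, they also leave open whether the same exchange of chloro for hydrogen would read the same with 3-fluorophenyl or naphthalen-1-yl on the amide-type nitrogen, as the one pair available here carries 3-chlorophenyl.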